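The compounds below may be only part of what the source reports. "The series", "measured", "known", "first", "only" and "open" are said of these compounds alone.

Measured so far: compound 1 `CCCCCCCCCCCCCC(=O)Nc1nnc(S[C@@H]2O[C@H](COC(C)=O)[C@H](OC(C)=O)[C@H](OC(C)=O)[C@H]2OC(C)=O)s1`, 34700 nM; compound 2 `CCCCCCCC/C=C\CCCCCCCCCCCC(=O)Nc1nnc(S[C@@H]2O[C@H](COC(C)=O)[C@H](OC(C)=O)[C@H](OC(C)=O)[C@H]2OC(C)=O)s1`, 28400 nM; compound 3 `CCCCCCCCCCCCCC(=O)Nc1nnc(S[C@@H]2O[C@H](CO)[C@H](O)[C@H](O)[C@H]2O)s1`, "not active" (no number reported), with no number given.

In a functional assay on DU-145 cells (Homo sapiens) for cytotoxicity, read by MTT assay, with a stated time of 24 h (a lower number here means a stronger inhibitor, a higher number a weaker inhibitor), compound 1 gives 34700 nM, and compound 2 gives 28400 nM. The change between them, (dec-1-en-1-yl in place of ethyl on a saturated chain carbon, ten or more bonds along the chain from a carbonyl carbon), produced a 1.2-fold lower number from compound 1 to compound 2 (0.09 log units; within the scatter). Compound 3 carries the same tetradecanoyl chain as compound 1 on a different core; the difference between the two cores is not broken down here. In this assay compound 3 was reported as not active without a number.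

Compound 4 `CCCCCCCC/C=C\CCCCCCCCCCCC(=O)Nc1nnc(S[C@@H]2O[C@H](CO)[C@H](O)[C@H](O)[C@H]2O)s1` applies the same change to compound 3: dec-1-en-1-yl in place of ethyl on a saturated chain carbon, ten or more bonds along the chain from a carbonyl carbon. Since this step on the acetylated core gave a 1.2-fold lower number from compound 1 to compound 2 (0.09 log units; within the scatter), a step within the scatter, and compound 3 itself was reported inactive, compound 4 is expected to remain weak. The expected value for compound 4 in this assay is 100000 nM, within 30000 nM to 400000 nM, with a real chance that only a limit is reported.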

Compound 4, half-maximal inhibitory concentration: "not active" (no number reported)
Nothing numeric was reported for compound 4, so the estimate cannot be set against anything.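

Compound 3 and compound 4 were both reported as not active, without a number, in this assay, so no step can be read between them. The compounds shown leave open how far the chain change shifts activity on this core. No measured evidence bears on this result.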